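The source may hold more compounds than are shown below. What is called first, only, known or untested is meant among the compounds shown, and "the series" means these compounds.

Three compounds share one core, a sulfonyl-linked six-membered ring bearing two nitrogens, and all three have been tested in an ADME assay on HEK-293T cells (Homo sapiens) for cytotoxicity, read by CCK-8 assay, with a stated time of 48 h; a lower number here means a stronger inhibitor, a higher number a weaker inhibitor. Compound 1, `O=C(Nc1cccc([N+](=O)[O-])c1)N1CCN(S(=O)(=O)c2sccc2-c2ccccc2Oc2ccc(O)c(O)c2)CC1`, reaches only the limit of the assay, giving > 20000 nM. Compound 2, `O=S(=O)(c1sccc1-c1ccccc1Oc1ccc(O)c(O)c1)N1CCN(C(=S)Nc2cc(C(F)(F)F)cc(C(F)(F)F)c2)CC1`, also stops at a limit, with > 20000 nM. Compound 3, `COc1ccc(Oc2ccccc2-c2ccsc2S(=O)(=O)N2CCN(C(=O)Nc3cccc([N+](=O)[O-])c3)CC2)cc1OC`, likewise gives a limit, > 20000 nM. Compound 3 differs from compound 1 by 3,4-dimethoxyphenyl in place of 3,4-dihydroxyphenyl on an oxygen on an aromatic ring, yet the step that the two limits leave unreadable from compound 1 to compound 3 cannot be read, since both ends are limits. So compound 3 stands where every measured compound stands: at the limit of > 20000 nM in this assay, at which 3 of the 3 values shown sit, with no number beneath it.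

Compound 4, `COc1ccc(Oc2ccccc2-c2ccsc2S(=O)(=O)N2CCN(C(=S)Nc3ccc(Cl)cc3)CC2)cc1OC`, is not yet measured. It differs from compound 3 by a group of 10 heavy atoms (7 carbon, 1 nitrogen, 1 sulfur, 1 chlorine; one six-membered aromatic ring of carbon only) in place of a group of 12 heavy atoms (7 carbon, 2 nitrogen, 3 oxygen; one six-membered aromatic ring of carbon only), on an amine nitrogen in a ring. No measured step touches this place, and the one step shown is unreadable, so no size can be carried over. Three limits in a row suggest that compound 4 will also sit at the limit in this assay, meaning an expected step that the limit leaves unreadable from compound 3 to compound 4, that is, none beyond the scatter. The expected value for compound 4 in this assay is therefore 30000 nM, with a range from 12000 nM to 100000 nM.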

Compound 4, half-maximal inhibitory concentration: > 20000 nM
Compound 4: no number, only a limit; the forecaster's own chance of this, stated with the estimate: 80%; the middle value is on the limit's open side.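

Compound 3 and compound 4 both give only a limit in this assay, so the step between them cannot be read. All the compounds shown share that result: the limit of > 20000 nM in this assay, at which 4 of the 4 values shown sit.

The compounds shown leave open what number any of them would give in the read-out, and how any change of group would shift it.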